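The source may hold more compounds than are shown below. What is called first, only, known or untested is meant among the compounds shown, and "the series" means these compounds.

Measured so far:
- compound 1, `Cc1ccc(-c2c[nH]nc2S(=O)(=O)CC2=NCCS2)cc1`; in a functional assay, tested at 50 ug/mL (on this read-out lower numbers stand for a weaker effect and higher numbers for a stronger effect at the one concentration tested), compound 1 gives "not active" (no number reported)
- compound 2, `COc1ccc(C2=NOC(c3ccc(C)cc3)C2S(=O)(=O)CC2=NCCS2)cc1`; in this assay compound 2 gives 47.5%
- compound 3, `O=S(=O)(CC1=NCCO1)C1=NNCC1c1ccccc1`; in this assay compound 3 gives "not active" (no number reported)

Compound 1 stands without a number of its own: the only report is that it showed no activity. Compound 3 carries the same kind of report. For the measured compounds named here, only compound 2 has a figure, and no step between any of these three is worked out, so all that can be said is that compound 2 shows a measurable effect where compound 1 and compound 3 show none.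

Compound 4, `O=S(=O)(CC1=NCCS1)c1n[nH]cc1-c1ccc(Cl)cc1`, is not yet measured. It keeps the whole core of compound 1 and differs from it in a single group: chloro in place of methyl on an aromatic carbon.

Going by the values given here, with no measured step to lean on, the size of the change in this assay from compound 1 to compound 4 cannot be taken from data. The exchange of one group for another at the same place on the ring is the kind of move that usually shifts a read-out of this sort by no more than the scatter, and compound 1 starts from no activity at all. Compound 4 is therefore expected to give 12%, in a range from 0% to 35%, with a fair chance that no number but only an inactive report comes back.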

Compound 4, a percentage reported as activity, at one concentration (the size of the read-out at that concentration, not a potency): "not active" (no number reported)
Compound 4 has no reported number here, and the estimate cannot be compared.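

In this assay, for the compounds shown here, compound 1 gives "not active" (no number reported) and compound 4 gives "not active" (no number reported) so no step between the two can be read. The compounds shown leave open whether going from 4-methylphenyl to 4-chlorophenyl changes the effect at all. Nothing else measured here bears on this result.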